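A few compounds are considered here, and "the series" means these few. Any claim that something is new, unique, unknown or untested is made for them only; others in the source may bear on it.

In an ADME assay on Sf9 cells for inhibition of Dipeptidyl peptidase 9 (Homo sapiens), read by fluorescence, with stated times of 60 s and 20 min (on this read-out lower numbers stand for stronger inhibition and higher numbers for weaker inhibition), compound 1 `CC#CCn1c(N2CCC[C@@H](N)C2)cc(=O)n(Cc2cc(Br)ccc2C(=O)O)c1=O` gives only a limit, > 100000 nM. Compound 2 `CC#CCn1c(N2CCC[C@@H](N)C2)cc(=O)n(Cc2cc(OC)ccc2C(=O)O)c1=O` also gives only a limit in this assay, > 100000 nM. Both values sit at the limit of > 100000 nM in this assay, at which 2 of the 2 values shown sit, so the step that the two limits leave unreadable from compound 1 to compound 2 has no readable size or direction. Compound 3 `CC#CCn1c(N2CCC[C@@H](N)C2)cc(=O)n(Cc2cc(C#N)ccc2C(=O)O)c1=O` differs from compound 2 by cyano in place of methoxy on an aromatic carbon. Going by the values given here, since the one measured step gives no readable size, it offers no direction for the new change. Compound 3 is therefore expected to stay near the limit, at an estimated 200000 nM with a range from 50000 nM to 800000 nM. For compound 3 the expected step is a step that the limit leaves unreadable from compound 2 to compound 3.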

Compound 3, half-maximal inhibitory concentration: > 100000 nM
Compound 3 was reported as a limit; the forecaster's own chance of this, stated with the estimate: 85%; the middle value does not contradict the limit.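

No step among compound 1, compound 2 and compound 3 can be read, since each result is only a limit: the limit of > 100000 nM in this assay, at which 3 of the 3 values shown sit.

The compounds shown leave open how strongly each inhibits in this assay, and whether exchanging bromo, methoxy and cyano changes that at all.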